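A Trifluorophenyl Replaces a Biphenyl in a Weak Inhibitor

This account rests on a few compounds, and the source may have more. Where it says the series, first, only, none or still open, it means among the compounds named here.

Within the data shown here, compound 1, `CC(C)[C@H](NC(=O)COc1cccc2ccccc12)C(=O)N[C@@H](CC(=O)O)C(=O)COc1ccc(-c2ccccc2)cc1`, is the only compound here with a measured number. In a functional assay on Jurkat cells (Homo sapiens) (a lower number here means a stronger inhibitor, a higher number a weaker inhibitor), compound 1 gives 87900 nM, a weak result. Compound 2, `CC(C)[C@H](NC(=O)COc1cccc2ccccc12)C(=O)N[C@@H](CC(=O)O)C(=O)COc1ccc(F)cc1`, carries fluoro in place of phenyl on an aromatic carbon. In this assay compound 2 reaches only a limit of the assay, > 100000 nM, so no number is known for it. The step of an at least 1.1-fold higher number from compound 1 to compound 2 (0.05 log units; that floor lies within the scatter) shows that this change brought no gain, and the limit of > 100000 nM in this assay, at which 1 of the 2 values shown sits, marks where one of the two results sits.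

Compound 3, `CC(C)[C@H](NC(=O)COc1cccc2ccccc12)C(=O)N[C@@H](CC(=O)O)C(=O)COc1c(F)ccc(F)c1F`, differs from compound 1 in one place: 2,3,6-trifluorophenyl in place of 4-phenylphenyl on an oxygen on a saturated carbon. Among the measured compounds shown here, only the step from compound 1 to compound 2 bears on this change, since it also removes the second aromatic ring and brings in fluorine; that step was an at least 1.1-fold higher number from compound 1 to compound 2 (0.05 log units; that floor lies within the scatter), at its floor within the scatter. The same direction, a higher number, is expected here. Compound 3 is therefore expected to give 150000 nM in this assay, between 60000 nM and 400000 nM. The expected step of a 1.7-fold higher number from compound 1 to compound 3 (0.23 log units; within the scatter) means weaker inhibition, and a limit rather than a number is the likelier outcome.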

Compound 3, half-maximal inhibitory concentration: 1200 nM
Estimate against measurement, compound 3: 130-fold (2.10 log units) above, outside the stated range (below it).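

The group on the oxygen on a saturated carbon has a large effect in this assay: putting 2,3,6-trifluorophenyl in place of 4-phenylphenyl gives a 73-fold lower number from compound 1 to compound 3 (1.86 log units; beyond the scatter), so the second aromatic ring is not needed for activity in this series, and one ring with the right substituents does far better than two. Compound 2 gives > 100000 nM as its result, which is a limit of the assay and not a number. Going from 4-fluorophenyl to 2,3,6-trifluorophenyl gives an at least 83-fold lower number from compound 2 to compound 3 (1.92 log units; beyond the scatter), so a fluorine on the ring does not by itself bring the gain, and the number of fluorines, their places on the ring, or both must matter.

The compounds shown give no measurement that explains why the trifluorophenyl group does so much better. From the compounds shown here alone, it remains open whether all three fluorines are needed, and how a chlorophenyl or a pyridyl ring would behave on the same oxygen.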